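Adding a Methoxy Group to the Phenoxy Ring

The source may hold more compounds than are shown below. What is called first, only, known or untested is meant among the compounds shown, and "the series" means these compounds.

Three compounds share one core and differ only in the group held on an aromatic carbon of that core. Compound 1 `Fc1ccc(-c2ccc3c(NCCCNCc4ccco4)ccnc3c2)cc1` carries 4-fluorophenyl there, compound 2 `CC(C)Cc1ccc2c(NCCCNCc3ccco3)ccnc2c1` carries isobutyl, and compound 3 `c1ccc(Oc2ccc3c(NCCCNCc4ccco4)ccnc3c2)cc1` carries phenoxy. In a physicochemical assay for acid dissociation, compound 1 gives 9.47, compound 2 gives 9.47, and compound 3 gives 9.28. As written, the number for compound 3 is the lowest of the three, yet its gap to each of the others falls within the scatter, so no real order can be read from them. The step of a number 0.19 log units lower from compound 1 to compound 3 (within the scatter) and the step of a number 0.19 log units lower from compound 2 to compound 3 (within the scatter) both stay within the scatter, as does no change at the digits printed from compound 1 to compound 2 (within the scatter).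

Compound 4 `COc1ccccc1Oc1ccc2c(NCCCNCc3ccco3)ccnc2c1` is reached from compound 3 by methoxy in place of hydrogen on an aromatic carbon, ortho to a large group. Within the data shown here, no measured step covers this exact change; all three measured steps, however, exchanged whole groups on an aromatic carbon of the core without moving the number beyond the scatter. A smaller addition is therefore expected to leave this assay essentially unchanged, with a number 0.02 log units higher from compound 3 to compound 4 (within the scatter) within the scatter. Compound 4 is estimated at 9.3, with a range from 9 to 9.6.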

Compound 4, acid dissociation constant: 9.28
The estimate for compound 4 lay 0.02 log units above the measured number, within the range that was stated.
By their numbers in this assay, from the lowest: compounds 3, 4, 1 and 2 (each within the scatter of the next).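

In this assay, among these compounds, adding methoxy to the phenoxy ring, on an aromatic carbon ortho to a large group, gives no change at the digits printed from compound 3 to compound 4 (within the scatter) and so adds something new: the earlier steps exchanged one whole group for another on the shared core, whereas this one alters a group already in place, and the measurement cannot tell the two compounds apart. The 2-methoxyphenoxy group also cannot be separated from the two other groups in this assay, with a number 0.19 log units lower from compound 2 to compound 4 (within the scatter) and with a number 0.19 log units lower from compound 1 to compound 4 (within the scatter), so repeated measurements alone could account for every difference among these compounds. Nothing available explains why the number stays within the scatter for this change.

As far as these compounds go, it remains open whether a group of a different kind on the phenoxy ring, such as an amine or a carboxylic acid, would move the number beyond the scatter. Also open, from the compounds shown here alone, is whether altering the chain shared by all four compounds, for example by making it a longer chain, would do so.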